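Shifting a methyl onto the piperazine of a camphor ester

A few compounds are considered here, and "the series" means these few. Any claim that something is new, unique, unknown or untested is made for them only; others in the source may bear on it.

Three esters of the same bicyclic alcohol have been tested in an ADME assay on MDCK cells (Canis lupus familiaris) for cytotoxicity, read by MTT assay, with a stated time of 48 h; on this read-out lower numbers stand for higher toxicity in this test and higher numbers for lower toxicity in this test. Compound 1 `CC1(C)[C@H]2CC[C@]1(C)[C@H](OC(=O)CN1CCCCC1)C2` gives 138000 nM. Compound 2 `CC1(C)[C@H]2CC[C@]1(C)[C@H](OC(=O)CCN1CCNCC1)C2` gives 12600 nM, the lowest number among the three. Compound 3 `CCN1CCN(CCC(=O)O[C@@H]2C[C@@H]3CC[C@@]2(C)C3(C)C)CC1` gives 105000 nM. The step of an 11-fold lower number from compound 1 to compound 2 (1.04 log units; beyond the scatter) and the step of an 8.3-fold higher number from compound 2 to compound 3 (0.92 log units; beyond the scatter) frame compound 2 on both sides.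

Compound 4 `CN1CCN(CC(=O)O[C@@H]2C[C@@H]3CC[C@@]2(C)C3(C)C)CC1` differs from compound 2 by 4-methylpiperazin-1-yl in place of (piperazin-1-yl)methyl on a saturated chain carbon bound to a carbonyl carbon. Among the compounds with values here, the closest precedent is compound 3, whose methyl-free amine nitrogen of compound 2 received an ethyl, giving an 8.3-fold higher number from compound 2 to compound 3 (0.92 log units; beyond the scatter). Because that step an 8.3-fold higher number from compound 2 to compound 3 (0.92 log units; beyond the scatter) raised the number well beyond the scatter, a rise of similar order is expected here, and the step of a 5.6-fold higher number from compound 2 to compound 4 (0.74 log units; beyond the scatter) is the estimate. Compound 4 is therefore expected to give 70000 nM, within a range of 25000 nM to 200000 nM.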

Compound 4, half-maximal cytotoxic concentration: 103000 nM
Beside the measured number, compound 4's estimate is 1.5-fold (0.17 log units) below it; the range from low to high includes it.
By their numbers in this assay, from the lowest: compound 2; then compounds 4, 3 and 1 (each within the scatter of the next).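

Moving the same atoms around is enough to produce an 8.2-fold higher number from compound 2 to compound 4 (0.91 log units; beyond the scatter), and the entering 4-methylpiperazin-1-yl has no hydrogen-bond donor, whereas the leaving group has one. At this saturated chain carbon bound to a carbonyl carbon, a 1.3-fold lower number from compound 1 to compound 4 (0.13 log units; within the scatter) shows that 4-methylpiperazin-1-yl and piperidin-1-yl cannot be told apart in this assay. Nothing measured here explains these steps.

From the compounds shown here alone, compound 4 differs from compound 2 in both chain length and the methyl on the ring nitrogen, so the share of each stays open. An unsubstituted piperazin-1-yl on the same carbon would help separate the two.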